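Swapping Fluoro for Methoxy: Estimating Compound 4

The compounds below may be only part of what the source reports. "The series", "measured", "known", "first", "only" and "open" are said of these compounds alone.

Measured so far in a functional assay on MCF7 cells (Homo sapiens) for cytotoxicity, read by MTT assay, with a stated time of 2 days, tested at 10 uM; on this read-out lower numbers stand for a stronger effect and higher numbers for a weaker effect at the one concentration tested:
compound 1 `CC(=O)c1cc(-c2ccccc2)cc2cc(-c3ccccc3)[nH]c12` gives 96.2%
compound 2 `CC(=O)c1cc(-c2ccccc2)cc2cc(-c3ccc(F)cc3)[nH]c12` gives 91.9%
compound 3 `COc1ccc(-c2cc(C(C)=O)c3[nH]c(-c4ccc(F)cc4)cc3c2)cc1` gives 52.9%

Compound 2 stands second highest of the three: its gap to compound 1, a number 4.3 percentage points lower from compound 1 to compound 2 (within the scatter), lies within the scatter, whereas compound 3 lies far below it. Compound 4 `COc1ccc(-c2cc3cc(-c4ccccc4)cc(C(C)=O)c3[nH]2)cc1` differs from compound 2 in one place: methoxy in place of fluoro on an aromatic carbon. For the measured compounds named here, two measured steps bear on this. Fluoro entering in place of hydrogen changed little, a number 4.3 percentage points lower from compound 1 to compound 2 (within the scatter). Methoxy entering in place of hydrogen, a number 39 percentage points lower from compound 2 to compound 3 (beyond the scatter), was a large drop, though there the fluoro stayed rather than being replaced. A methoxy entering is therefore expected to lower the number: compound 4 is expected to show a step of a number 23.9 percentage points lower from compound 2 to compound 4 (beyond the scatter), with an estimated value of 68% and a range from 45% to 92%.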

Compound 4, a percentage reported as activity, at one concentration (the size of the read-out at that concentration, not a potency): 64.5%
Compound 4: the middle estimate sits 3.5 percentage points above what was measured, within the range that was stated.
By their numbers in this assay, from the lowest: compound 3; then compound 4; then compounds 2 and 1 (each within the scatter of the next).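

Going from 4-fluorophenyl to 4-methoxyphenyl in this assay gives a step of a number 27.4 percentage points lower from compound 2 to compound 4 (beyond the scatter), so methoxy lowers the number here even when it replaces fluoro rather than hydrogen. Measured against hydrogen at this same place, the step is a number 31.7 percentage points lower from compound 1 to compound 4 (beyond the scatter). Methoxy entering therefore behaves much alike in two different places on the shared core: the same change on two cores in this assay, a number 39 percentage points lower (beyond the scatter) from compound 2 to compound 3 and a number 31.7 percentage points lower (beyond the scatter) from compound 1 to compound 4, 7.3 percentage points apart, within the scatter of two such steps

The compounds shown leave open how an amine, a carboxylic acid or a longer chain such as ethoxy would read at this place. They also leave open whether methoxy in both places would lower the number further.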